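Demethylation of a diaryl urea pyrazole against a breast cancer line

This account rests on a few compounds, and the source may have more. Where it says the series, first, only, none or still open, it means among the compounds named here.

Going by the values given here, compound 2 `COc1cc(-c2nn(-c3cccc(NC(=O)Nc4cc(C(F)(F)F)cc(C(F)(F)F)c4)c3)cc2-c2ccncc2)ccc1Cl` is the one compound with a firm number in a functional assay on Hs-578T cells (Homo sapiens) for inhibition, read by sulforhodamine B assay, with a stated time of 48 h (a higher number here means a weaker inhibitor of growth, a lower number a stronger inhibitor of growth), where compound 2 gives 3680 nM. Compound 1 `O=C(Nc1cccc(-n2cc(-c3ccncc3)c(-c3ccc(Cl)c(O)c3)n2)c1)Nc1cccc(C(F)(F)F)c1` reaches only a limit of the assay, giving > 32500 nM in this assay. The step to compound 3 `O=C(Nc1cccc(-n2cc(-c3ccncc3)c(-c3ccc(Cl)c(O)c3)n2)c1)Nc1cc(C(F)(F)F)cc(C(F)(F)F)c1` is hydrogen in place of methyl on an oxygen on an aromatic ring. Among the compounds with values here, no such step has been measured here; the hydroxy-bearing compound 1 sits at the limit of > 32500 nM in this assay, at which 1 of the 2 values shown sits, so compound 3 is expected to lose ground in this assay. Compound 3 is expected to give 15000 nM in this assay, within 4000 nM to 40000 nM, a step estimated as a 4.1-fold higher number from compound 2 to compound 3 (0.61 log units; beyond the scatter).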

Compound 3, concentration for total growth inhibition: 4080 nM
Compound 3: middle estimate off by 3.7-fold (0.57 log units), on the high side, within the range that was stated.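

In this assay, the change from methoxy to hydroxy on this aromatic ring leaves the number unchanged within the scatter (a 1.1-fold higher number from compound 2 to compound 3 (0.04 log units; within the scatter)), so a free hydroxy here is tolerated when the second trifluoromethyl is present. The large difference lies instead with trifluoromethyl in place of hydrogen on an aromatic carbon (an at least 7.9-fold lower number from compound 1 to compound 3 (0.90 log units; beyond the scatter)). From the compounds shown here alone, the true size of that step stays unknown, as compound 1 gives only a limit: the limit of > 32500 nM in this assay, at which 1 of the 3 values shown sits.

Going by these compounds, it remains open whether an ethoxy group or an amine at this position would hold the number of compound 3. On these data alone, the size of the trifluoromethyl step with methoxy in place of hydroxy is also open.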